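From isobutylsulfonyl to pentylsulfonyl on a shared core

A few compounds are considered here, and "the series" means these few. Any claim that something is new, unique, unknown or untested is made for them only; others in the source may bear on it.

Compound 1 `O=C(O)CCNC(=O)c1ccc2c(c1)C(=O)N(CCC1CCNCC1)C2`: 27 nM
Compound 2 `CS(=O)(=O)N[C@@H](CNC(=O)c1ccc2c(c1)C(=O)N(CCC1CCNCC1)C2)C(=O)O`: 14 nM
Compound 3 `CC(C)CS(=O)(=O)N[C@@H](CNC(=O)c1ccc2c(c1)C(=O)N(CCC1CCNCC1)C2)C(=O)O`: 9 nM

These values come from a functional assay for inhibition, with Homo sapiens as the target; on this read-out lower numbers stand for stronger inhibition and higher numbers for weaker inhibition. Compound 3 stands clear of compound 1, with a 3.0-fold lower number from compound 1 to compound 3 (0.48 log units; beyond the scatter), but not of compound 2, with a 1.6-fold lower number from compound 2 to compound 3 (0.19 log units; within the scatter).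

The next compound, compound 4 `CCCCCS(=O)(=O)N[C@@H](CNC(=O)c1ccc2c(c1)C(=O)N(CCC1CCNCC1)C2)C(=O)O`, differs from compound 3 in one place: butyl in place of isopropyl on a saturated chain carbon bound to a sulfonyl sulfur. In words, this is butyl in place of isopropyl on a saturated chain carbon bound to a sulfonyl sulfur, which can also be read as isobutylsulfonyl to pentylsulfonyl.

The most direct evidence is a single step at that carbon, a 1.6-fold lower number from compound 2 to compound 3 (0.19 log units; within the scatter), where isopropyl took the place of hydrogen. The step of a 1.9-fold lower number from compound 1 to compound 2 (0.29 log units; within the scatter) bears on the change less directly, as it introduced the methanesulfonamido group. Among the measured compounds shown here, no measured compound carries pentylsulfonyl, so the evidence is thin. On this basis, no step beyond the scatter is expected in this assay. The estimated change is a 1.1-fold lower number from compound 3 to compound 4 (0.05 log units; within the scatter). Compound 4 is expected at about 8 nM. The estimated range for compound 4 runs from 3.5 nM to 18 nM.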

Compound 4, half-maximal inhibitory concentration: 9 nM
The estimate for compound 4 lay 1.1-fold (0.05 log units) below the measured number, and the stated range covers the measured number.
By their numbers in this assay, from the lowest: compounds 3, 4, 2 and 1 (each within the scatter of the next, the first and the last beyond it).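

In this assay the read-out shows no change at the digits printed from compound 3 to compound 4 (within the scatter) when butyl takes the place of isopropyl on a saturated chain carbon bound to a sulfonyl sulfur, so this position accepts an unbranched pentylsulfonyl as well as a branched isobutylsulfonyl without a change that can be told from the scatter. The other two steps repeat the picture given by compound 3: there is a 1.6-fold lower number from compound 2 to compound 4 (0.19 log units; within the scatter) and so no clear separation from the methanesulfonamido compound, while there is a 3.0-fold lower number from compound 1 to compound 4 (0.48 log units; beyond the scatter) and so a modest gain that now rests on two sulfonamides rather than one, although compound 2 does not stand clear of compound 1. Nothing available here accounts for this flat response to the chain.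

The compounds shown leave open whether a chain longer than pentyl, or a ring such as phenyl or cyclohexyl in place of butyl, would stand clear of compound 2 and of compound 3. They also leave open whether an amine or a carboxylic acid at the end of the butyl chain would be accepted at this carbon as the plain chain is.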